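The source may report more compounds than this note shows. Statements on the series, on what has been measured and on what is new or still open speak of the compounds shown alone.

Measured compounds in an assay on membranes from lung (Cavia porcellus) for binding affinity to cysteinyl leukotriene receptor (Homo sapiens); a lower number here means a stronger inhibitor, a higher number a weaker inhibitor:
- Compound 1 `CC(CCC(=O)O)Cc1cccc(OCc2ccc3ccccc3n2)c1`: compound 1 gives 140 nM
- Compound 2 `O=C(O)CCCCc1cccc(OCc2ccc3ccccc3n2)c1`: compound 2 gives 100 nM
- Compound 3 `c1cc(OCCCc2nnn[nH]2)cc(OCc2ccc3ccccc3n2)c1`: compound 3 gives 42 nM

Among these three numbers compound 2 holds the second highest. Its nearest neighbour is compound 1, with a 1.4-fold lower number from compound 1 to compound 2 (0.15 log units; within the scatter); its furthest is compound 3, with a 2.4-fold lower number from compound 2 to compound 3 (0.38 log units; beyond the scatter). The step from compound 1 to compound 3 was a 3.3-fold lower number from compound 1 to compound 3 (0.52 log units; beyond the scatter).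

Compound 4 `O=C(O)CCC(Cc1cccc(OCc2ccc3ccccc3n2)c1)c1ccccc1` is not yet measured. It differs from compound 2 by phenyl in place of hydrogen on a saturated chain carbon bound to two saturated chain carbons. Among the compounds with values here, only one measured step touches this place: the change from compound 1 to compound 2, where methyl was swapped for hydrogen on the same saturated chain carbon, gave a 1.4-fold lower number from compound 1 to compound 2 (0.15 log units; within the scatter). That step shows the shown compounds tolerate a change at this position without a shift beyond the scatter, but a phenyl group is a larger entry than methyl, and no measured pair tells how this assay answers it. The expected step from compound 2 to compound 4 in this assay is therefore a 1.3-fold lower number from compound 2 to compound 4 (0.10 log units; within the scatter), with wide uncertainty. Compound 4 is estimated at 80 nM, in a range from 25 nM to 300 nM.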

Compound 4, inhibition constant: 52 nM
Estimate against measurement, compound 4: 1.5-fold (0.19 log units) above; the range from low to high includes it.
By their numbers in this assay, from the lowest: compounds 3, 4, 2 and 1 (each within the scatter of the next, the first and the last beyond it).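

In this assay a group of 6 heavy atoms, phenyl, on the saturated chain carbon bound to two saturated chain carbons gives a 1.9-fold lower number from compound 2 to compound 4 (0.28 log units; within the scatter) and so the position accepts a six-membered aromatic ring of carbon only without a shift beyond the scatter from hydrogen. Set against methyl on the same carbon, phenyl gives a 2.7-fold lower number from compound 1 to compound 4 (0.43 log units; beyond the scatter) and this is the first step at this position to lie beyond the scatter, though only modestly. No measurement shown here accounts for the difference between the phenyl and methyl compounds.

As far as these compounds go, it remains open how this assay would answer a benzyl group, a cyclohexyl ring or a hydroxyl group on this carbon. Also open, from the compounds shown here alone, is how phenyl at this carbon would read alongside the 3-(1H-tetrazol-5-yl)propoxy chain of compound 3.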